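Swapping trifluoromethyl for cyclopropyl on the aryl ring

The compounds below may be only part of what the source reports. "The series", "measured", "known", "first", "only" and "open" are said of these compounds alone.

Measured compounds:
compound 1 `Cc1cccc(-n2c(C)cc(C(=O)O)c2C)c1`: 1500 nM
compound 2 `Cc1cc(C(=O)O)c(C)n1-c1cccc(C(F)(F)F)c1`: 1500 nM

In an assay on cells for inhibition of Palmitoleoyl-protein carboxylesterase NOTUM variant C330S (Homo sapiens), read by fluorescence, with a stated time of 40 min (a lower number here means a stronger inhibitor, a higher number a weaker inhibitor), compound 2 stands level with compound 1 at the digits printed, and the step of no change at the digits printed from compound 1 to compound 2 (within the scatter) lies within the scatter. Compound 3 `Cc1cc(C(=O)O)c(C)n1-c1cccc(C2CC2)c1`, not yet measured, differs from compound 2 in one place: cyclopropyl in place of trifluoromethyl on an aromatic carbon. Going by the values given here, only one measured step touches this part of the shared core, the exchange of methyl for trifluoromethyl from compound 1 to compound 2, and it moved nothing beyond the scatter. Among the compounds with values here, there is no measured step with a cyclopropyl, so the expectation rests on that single neighbouring exchange. From it, the step of a 1.2-fold lower number from compound 2 to compound 3 (0.06 log units; within the scatter) in this assay is expected to be small, with no clear direction beyond the scatter. Compound 3 is therefore estimated at 1300 nM in this assay, with a range from 500 nM to 3500 nM.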

Compound 3, half-maximal inhibitory concentration: 580 nM
Estimate against measurement, compound 3: 2.2-fold (0.35 log units) above; the range from low to high includes it.
By their numbers in this assay, from the lowest: compound 3; then compounds 1 and 2 (each within the scatter of the next).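

On this aromatic carbon, meta to a large group, the exchange of methyl for trifluoromethyl had given no readable change, so the position could have seemed indifferent to what it carries. Cyclopropyl shows that it is not: in this assay it gives a 2.6-fold lower number from compound 2 to compound 3 (0.41 log units; beyond the scatter) and a 2.6-fold lower number from compound 1 to compound 3 (0.41 log units; beyond the scatter) as the two steps at this carbon that lie beyond the scatter. Why cyclopropyl separates from both other groups cannot be told from these data, and nothing measured bears on it.

Going by these compounds, whether a larger ring such as cyclobutyl or an open chain such as isopropyl would give a lower number still remains open. So does whether the carboxylic acid on the shared core could be exchanged for an amide or a tetrazole.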